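A few compounds are considered here, and "the series" means these few. Any claim that something is new, unique, unknown or untested is made for them only; others in the source may bear on it.

In a functional assay on A549 cells (Homo sapiens) for cytotoxicity, read by MTT assay, with a stated time of 24 h (on this read-out higher numbers stand for weaker inhibition and lower numbers for stronger inhibition), compound 1 `CN(C)CCN1CCN(CC(=O)Nc2ccc(-c3nc4cc(F)ccc4o3)cc2)CC1` gives 16600 nM, compound 2 `Cc1cc(-c2nc3cc(F)ccc3o2)ccc1NC(=O)CN1CCN(CCN(C)C)CC1` gives 7370 nM, and compound 3 `Cc1ccc2oc(-c3ccc(NC(=O)CN4CCN(CCCN(C)C)CC4)cc3)nc2c1` gives 10600 nM. Compound 3 therefore holds the second highest of the three numbers, yet it lies within the scatter of both compound 1 and compound 2, so no real order among them can be claimed. Compound 4 `Cc1ccc2oc(-c3ccc(NC(=O)CN4CCN(CCCN(C)C)CC4)c(C)c3)nc2c1` differs from compound 3 by methyl in place of hydrogen on an aromatic carbon, on an aromatic carbon of a six-membered aromatic ring of carbon only. Among the measured compounds shown here, the only measured step of the same kind, methyl in place of hydrogen on an aromatic carbon, is a 2.3-fold lower number from compound 1 to compound 2 (0.35 log units; beyond the scatter). A modest step toward a lower number is expected in this assay, about a 2.1-fold lower number from compound 3 to compound 4 (0.33 log units; beyond the scatter). Compound 4 is estimated at 5000 nM, with a range from 2300 nM to 11000 nM.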

Compound 4, half-maximal inhibitory concentration: 15300 nM
Estimate against measurement, compound 4: 3.1-fold (0.49 log units) below; measured number above the stated range.
By their numbers in this assay, from the lowest: compounds 2, 3, 4 and 1 (each within the scatter of the next, the first and the last beyond it).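

Adding a methyl at this position, ortho to a large group, does not give the same result on every core in this assay. On the core of compound 3, the step is a 1.4-fold higher number from compound 3 to compound 4 (0.16 log units; within the scatter), so the methyl brings no clear difference here. One earlier step therefore cannot predict the effect of this change on another core: the same change on two cores in this assay, a 2.3-fold lower number (0.35 log units; beyond the scatter) from compound 1 to compound 2 and a 1.4-fold higher number (0.16 log units; within the scatter) from compound 3 to compound 4, 3.3-fold (0.51 log units) apart, beyond the scatter of two such steps.

Going by these compounds, it remains open which difference between the two cores decides the outcome. It is also unclear whether another group at this position, such as chlorine, methoxy or an amine, would move the number beyond the scatter.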